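This account rests on a few compounds, and the source may have more. Where it says the series, first, only, none or still open, it means among the compounds named here.

In a functional assay on DU-145 cells (Homo sapiens) for antiproliferative activity, read by MTT assay, with a stated time of 72 h (on this read-out lower numbers stand for stronger inhibition and higher numbers for weaker inhibition), three compounds have been measured. Compound 1 `COc1cc2c(Nc3ccc(C#N)cc3)ncnc2cc1OCCCN1CCC(O)CC1` gives 74900 nM, compound 2 `CCN1CCN(CCCOc2cc3ncnc(Nc4ccc(C#N)cc4)c3cc2OC)CC1` gives 34400 nM, and compound 3 `COc1cc2c(Nc3ccc(C#N)cc3)ncnc2cc1OCCCN1CCN(c2ccncc2)CC1` gives 22900 nM. Compound 2 has one close neighbour, shown by a 1.5-fold lower number from compound 2 to compound 3 (0.18 log units; within the scatter), and one further off, shown by a 2.2-fold lower number from compound 1 to compound 2 (0.34 log units; beyond the scatter). The remaining measured step is a 3.3-fold lower number from compound 1 to compound 3 (0.51 log units; beyond the scatter).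

Compound 4 `CCN1CCN(CCCOc2cc3ncnc(Nc4ccccc4C#N)c3cc2OC)CC1` has not yet been measured. It differs from compound 2 by 2-cyanophenyl in place of 4-cyanophenyl on a nitrogen on an aromatic ring, with 2-cyanophenyl in place of 4-cyanophenyl on a nitrogen on an aromatic ring. All three measured steps change the group on the saturated chain, and none changes the cyanophenyl group, so they bear on this change only indirectly. The data give no direction for it, and no step beyond the scatter is expected in this assay, although this expectation is uncertain. The starting point is therefore compound 2 at 34400 nM. The expected step is a 1.0-fold higher number from compound 2 to compound 4 (0.02 log units; within the scatter). For compound 4 the estimate is 36000 nM, with an expected range from 13000 nM to 100000 nM.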

Compound 4, half-maximal inhibitory concentration: 5870 nM
Beside the measured number, compound 4's estimate is 6.1-fold (0.79 log units) above it; measured number outside the range, below it.
By their numbers in this assay, from the lowest: compound 4; then compounds 3 and 2 (each within the scatter of the next); then compound 1.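

In this assay, the cyanophenyl group on the nitrogen proves to be a position that affects the read-out: with the 4-ethylpiperazin-1-yl chain group held constant and the same atoms joined differently, 2-cyanophenyl in place of 4-cyanophenyl gives a 5.9-fold lower number from compound 2 to compound 4 (0.77 log units; beyond the scatter). The earlier compounds shown here varied only the group on the saturated chain, and their largest step was a 3.3-fold lower number from compound 1 to compound 3 (0.51 log units; beyond the scatter), so this change of attachment alone gives the larger step. Nothing shown accounts for the difference between the two cyanophenyl groups.

On these data alone, it remains open whether 2-cyanophenyl gives a similar step when paired with 4-hydroxypiperidin-1-yl or 4-(pyridin-4-yl)piperazin-1-yl on the chain. Also open, as far as these compounds go, is how a primary amide or a chlorine atom in place of the nitrile would read in this assay.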